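A few compounds are considered here, and "the series" means these few. Any claim that something is new, unique, unknown or untested is made for them only; others in the source may bear on it.

Measured in a functional assay on MCF7 cells (Homo sapiens) for cytotoxicity, read by sulforhodamine B assay, with a stated time of 48 h, tested at 100 uM; a lower number here means a stronger effect, a higher number a weaker effect of the compound at the concentration tested:

compound 1 `COc1ccc(-c2cc(/C=C/C(=O)c3ccc(N)cc3)[nH]n2)cc1`: -68%
compound 2 `COc1cc(-c2cc(/C=C/C(=O)c3ccc(N)cc3)[nH]n2)cc(OC)c1OC`: -57%
compound 3 `COc1cc(-c2cc(/C=C/C(=O)c3ccc(F)c(F)c3)[nH]n2)cc(OC)c1OC`: -20%

Compound 2 stands second highest of these three numbers: compound 1 lies a number lower, beyond the scatter, and compound 3 a number higher, the step of a number 37 percentage points higher from compound 2 to compound 3 (beyond the scatter) being large and exchanging the group on the carbonyl carbon. Compound 4 `COc1ccc(-c2cc(/C=C/C(=O)c3ccc(N)cc3)[nH]n2)cc1OC` differs from compound 2 by hydrogen in place of methoxy on an aromatic carbon. Within the data shown here, no measured step touches this part of the molecule, and the single measured step, a number 37 percentage points higher from compound 2 to compound 3 (beyond the scatter), concerns the other end and does not bear on it. Compound 1, which carries one methoxy group on that ring, gives -68%, not far from compound 2. Compound 4 is therefore expected to change only a number 5 percentage points lower from compound 2 to compound 4 (within the scatter), within the scatter. The estimate for compound 4 is -62%, between -80% and -44%.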

Compound 4, a percentage reported as activity, at one concentration (the size of the read-out at that concentration, not a potency): -58%
The estimate for compound 4 lay 4 percentage points below the measured number; measured number inside the range.
By their numbers in this assay, from the lowest: compounds 1, 4 and 2 (each within the scatter of the next, the first and the last beyond it); then compound 3.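

In this assay, among these compounds, the first look at this ring position shows that hydrogen can replace the methoxy group with little consequence: a number 1 percentage points lower from compound 2 to compound 4 (within the scatter). The matching step on the ring, methoxy in place of hydrogen, also stays small, a number 10 percentage points higher from compound 1 to compound 4 (within the scatter), so neither single exchange gives a change that can be told from the scatter. Nothing measured here offers an explanation for this tolerance. On these data alone, what a hydroxyl group or a chlorine atom would do at this place remains open. So does whether the same exchange behaves alike with 3,4-difluorophenyl on the carbonyl carbon.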